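The compounds below may be only part of what the source reports. "The series", "measured", "known", "first", "only" and "open" are said of these compounds alone.

Compound 1 `Oc1ccccc1/C=N/n1cnnc1` and compound 2 `COc1cccc(/C=N/n2cnnc2)c1O` share a core and differ by methoxy in place of hydrogen on an aromatic carbon. In a functional assay on PC-3 cells (Homo sapiens) for cytotoxicity (on this read-out lower numbers stand for stronger inhibition and higher numbers for weaker inhibition), compound 1 gives only a limit of the assay, > 30000 nM. Compound 2 likewise gives only a limit in this assay, > 30000 nM. The step that the two limits leave unreadable from compound 1 to compound 2 cannot be read, because both values sit at the limit of > 30000 nM in this assay, at which 3 of the 3 values shown sit. Compound 3 `COc1ccc(/C=N/n2cnnc2)cc1` also gives only a limit in this assay, > 30000 nM. How the core of compound 3 differs from the core of compound 1 is not broken down here. Compound 4 `COc1ccc(/C=N/n2cnnc2)cc1OC` differs from compound 3 by methoxy in place of hydrogen on an aromatic carbon, the same kind of change as from compound 1 to compound 2, though here the entering group sits ortho to a methoxy group rather than ortho to a hydroxy group. For compound 4 the step that the limit leaves unreadable from compound 3 to compound 4 is expected to be small, because every value shown sits at the limit of > 30000 nM in this assay, at which 3 of the 3 values shown sit. Compound 4 is therefore estimated at 50000 nM, most likely again as a limit only.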

Compound 4, half-maximal inhibitory concentration: > 30000 nM
Compound 4 gave a limit, no number; the forecaster's own chance of this, stated with the estimate: 85%; the middle value does not contradict the limit.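

The step from compound 3 to compound 4 cannot be read, because both compounds sit at the same limit: (the limit of > 30000 nM in this assay, at which 4 of the 4 values shown sit). From the compounds shown here alone, whether any change to the shared core gives a readable number in this assay stays open.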